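Oxamide nitrogen substituent: from 2-chlorophenyl to naphthalen-1-yl

The source may hold more compounds than are shown below. What is called first, only, known or untested is meant among the compounds shown, and "the series" means these compounds.

Among the measured compounds shown here, compound 3 `C[C@H](NC(=O)C(=O)Nc1ccccc1Cl)C(=O)N[C@@H](CC(=O)O)C(=O)COc1c(F)c(F)cc(F)c1F` gives 64 nM in a functional assay on Jurkat cells (Homo sapiens) for inhibition (a lower number here means a stronger inhibitor, a higher number a weaker inhibitor), the lowest of the three numbers so far. Compound 1 `C[C@H](NC(=O)C(=O)NC1CCCCC1)C(=O)N[C@@H](CC(=O)O)C(=O)COc1c(F)c(F)cc(F)c1F` gives 150 nM and compound 2 `C[C@H](NC(=O)C(=O)NCc1ccccc1)C(=O)N[C@@H](CC(=O)O)C(=O)COc1c(F)c(F)cc(F)c1F` gives 300 nM. The steps of a 2.3-fold lower number from compound 1 to compound 3 (0.37 log units; beyond the scatter) and a 4.7-fold lower number from compound 2 to compound 3 (0.67 log units; beyond the scatter) both run toward the 2-chlorophenyl compound, while a 2.0-fold higher number from compound 1 to compound 2 (0.30 log units; within the scatter) is within the scatter.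

Compound 4 `C[C@H](NC(=O)C(=O)Nc1cccc2ccccc12)C(=O)N[C@@H](CC(=O)O)C(=O)COc1c(F)c(F)cc(F)c1F` has not yet been measured in this assay. It differs from compound 3 by naphthalen-1-yl in place of 2-chlorophenyl on an amide-type nitrogen. For the measured compounds named here, no measured step exchanges one ring attached directly to this nitrogen for another; the two steps that bear on it, compound 1 to compound 3 and compound 2 to compound 3, only show that a ring directly on the amide-type nitrogen gave modestly lower numbers than cyclohexyl or benzyl. With naphthalen-1-yl keeping a ring directly on that nitrogen, the number for compound 4 is expected to stay close to that of compound 3, with a step of a 1.2-fold lower number from compound 3 to compound 4 (0.07 log units; within the scatter) that is expected to lie within the scatter. Compound 4 is therefore estimated at 55 nM, within a range of 20 nM to 160 nM.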

Compound 4, half-maximal inhibitory concentration: 86 nM
For compound 4 the middle estimate is 1.6-fold (0.19 log units) below the measured one, within the range that was stated.
By their numbers in this assay, from the lowest: compounds 3, 4, 1 and 2 (each within the scatter of the next, the first and the last beyond it).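

In this assay the exchange of one ring attached directly to the amide-type nitrogen for another can now be read: a 1.3-fold higher number from compound 3 to compound 4 (0.13 log units; within the scatter) shows that naphthalen-1-yl, with its second aromatic ring and no chlorine, gives no separable shift from 2-chlorophenyl at this position. Against benzyl the gap holds for this second directly attached ring (a 3.5-fold lower number from compound 2 to compound 4 (0.54 log units; beyond the scatter)), but against cyclohexyl it does not (a 1.7-fold lower number from compound 1 to compound 4 (0.24 log units; within the scatter)), so the separation from cyclohexyl rests on compound 3 alone. No measurement bears on the cause of these steps.

From the compounds shown here alone, it remains open how phenyl without chlorine, or a phenyl ring carrying an amine or a carboxylic acid, would compare with compound 3. A longer chain in place of benzyl also remains untested among the compounds shown here.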